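A few compounds are considered here, and "the series" means these few. Any claim that something is new, unique, unknown or untested is made for them only; others in the source may bear on it.

Measured:
Compound 1 `CC(O)(COc1ccc(C(F)(F)F)cc1)C(=O)Nc1cccc(S(F)(F)(F)(F)F)c1` gives 13600 nM in a functional assay on DU-145 cells (Homo sapiens) for antiproliferative activity, read by propidium iodide staining, with a stated time of 96 h; on this read-out lower numbers stand for stronger inhibition and higher numbers for weaker inhibition.
Compound 2 `CC(O)(COc1ccccc1C(F)(F)F)C(=O)Nc1cccc(S(F)(F)(F)(F)F)c1` gives 52200 nM in this assay.

For the measured compounds named here, compound 2 stands highest of the two numbers; the only comparison is a 3.8-fold higher number from compound 1 to compound 2 (0.58 log units; beyond the scatter), a modest step. Compound 3 `CC(O)(COc1ccc(C#N)c(F)c1)C(=O)Nc1cccc(S(F)(F)(F)(F)F)c1` differs from compound 2 by 4-cyano-3-fluorophenyl in place of 2-(trifluoromethyl)phenyl on an oxygen on a saturated carbon. Going by the values given here, no measured step covers this exact change, but compound 1 shows a 4-substituted phenyl giving the lower number. Compound 3 is therefore expected to move back toward compound 1, a step of a 3.5-fold lower number from compound 2 to compound 3 (0.54 log units; beyond the scatter). The estimate for compound 3 in this assay is 15000 nM, within 5000 nM to 50000 nM.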

Compound 3, half-maximal inhibitory concentration: 74800 nM
Beside the measured number, compound 3's estimate is 5.0-fold (0.70 log units) below it, outside the stated range (above it).
By their numbers in this assay, from the lowest: compound 1; then compounds 2 and 3 (each within the scatter of the next).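

In this assay 4-cyano-3-fluorophenyl in place of 4-(trifluoromethyl)phenyl gives a 5.5-fold higher number from compound 1 to compound 3 (0.74 log units; beyond the scatter), so among these three groups the lower number stays with 4-(trifluoromethyl)phenyl. Against 2-(trifluoromethyl)phenyl the same group gives a 1.4-fold higher number from compound 2 to compound 3 (0.16 log units; within the scatter), which leaves those two groups unseparated on this read-out. No measurement on hand bears on the reason for either step. As far as these compounds go, the nitrile and the fluorine enter together in compound 3, so their separate contributions remain open. Also open, from the compounds shown here alone, is how an amine or a carboxylic acid on the phenyl would read here.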